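The compounds below may be only part of what the source reports. "The series", "measured", "known", "first", "only" and "open" are said of these compounds alone.

Measured so far in an assay on isolated protein for inhibition of leukotriene B4 receptor 1 (Homo sapiens), tested at 10 uM; a lower number here means less inhibition, a higher number more inhibition at the concentration tested (going by the name of the read-out):
compound 1 `CC(=O)c1cc(C)c(OCCCCC#N)cc1O` gives 79%
compound 2 `CCCCCc1cc(C(C)=O)c(O)cc1OCCCCC#N` gives 31%
compound 3 `C=CCc1cc(C(C)=O)c(O)cc1OCC#N` gives 20%

Compound 3 stands lowest of the three numbers, beyond the scatter from compound 2 and further still from compound 1. Compound 4 `C=CCc1cc(C(C)=O)c(O)cc1OCCCCCC(C)=O` differs from compound 3 by 4-acetylbutyl in place of cyano on a saturated chain carbon bound to an oxygen on an aromatic ring. Among the compounds with values here, the one measured step, a number 48 percentage points lower from compound 1 to compound 2 (beyond the scatter), altered a chain on an aromatic carbon and not the chain on the ether oxygen, so it bears on this change only loosely, and no measured pair exchanges the cyano. The expectation is therefore a step of a number 5 percentage points higher from compound 3 to compound 4 (within the scatter) in this assay, within the scatter. Compound 4 is estimated at 25%, between 5% and 50%.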

Compound 4, a percentage reported as inhibition, at one concentration (the size of the read-out at that concentration, not a potency): 98%
For compound 4 the middle estimate is 73 percentage points below the measured one; measured number outside the range, above it.
By their numbers in this assay, from the lowest: compound 3; then compound 2; then compound 1; then compound 4.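

In this assay, within the data shown here, 4-acetylbutyl in place of cyano on a saturated chain carbon bound to an oxygen on an aromatic ring gives a number 78 percentage points higher from compound 3 to compound 4 (beyond the scatter) and is the only measured change at this position. The read-out therefore responds strongly to this chain, although each group carries a hydrogen-bond acceptor. No measurement shown accounts for the step. On these data alone, whether it follows the chain's length or its carbonyl stays open. A plain hexyl group or a carboxylic acid in place of 4-acetylbutyl would separate the two.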